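Thiophene ester against thiophene sulfonate at the P2X7 receptor

The compounds below may be only part of what the source reports. "The series", "measured", "known", "first", "only" and "open" are said of these compounds alone.

Measured so far in an assay on HEK293 cells for antagonist activity at P2X purinoceptor 7 (Homo sapiens), read by fluorescence, with a stated time of 2 h; a lower number here means a stronger inhibitor, a higher number a weaker inhibitor:
- compound 1 `CC(=O)Oc1ccc(-c2cncn2C2CCN(C(=O)c3ccc(Cl)c(C(F)(F)F)c3)CC2)cc1` gives > 10000 nM, which is a limit of this assay.
- compound 2 `O=C(Oc1ccc(-c2cncn2C2CCN(C(=O)c3ccc(Cl)c(C(F)(F)F)c3)CC2)cc1)c1ccccc1` gives > 10000 nM, which is a limit of this assay.
- compound 3 `O=C(c1ccc(Cl)c(C(F)(F)F)c1)N1CCC(n2cncc2-c2ccc(OS(=O)(=O)c3cccs3)cc2)CC1` gives 238 nM.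

Among the measured compounds shown here, compound 3 is the only compound of the three with a number in this assay; the other two sit at the limit of > 10000 nM in this assay, at which 2 of the 3 values shown sit. The step that the two limits leave unreadable from compound 1 to compound 2 stays unreadable for that reason. Both steps toward compound 3 are large: an at least 42-fold lower number from compound 1 to compound 3 (1.62 log units; beyond the scatter) and an at least 42-fold lower number from compound 2 to compound 3 (1.62 log units; beyond the scatter).

Compound 4 `O=C(Oc1ccc(-c2cncn2C2CCN(C(=O)c3ccc(Cl)c(C(F)(F)F)c3)CC2)cc1)c1cccs1` differs from compound 3 in one place: (thiophen-2-yl)carbonyl in place of (thiophen-2-yl)sulfonyl on an oxygen on an aromatic ring. The change keeps the thiophene and takes away the sulfonyl, leaving a carbonyl ester of the same kind as in compound 1 and compound 2, which both sit at the limit (the limit of > 10000 nM in this assay, at which 2 of the 3 values shown sit). The measured step of an at least 42-fold lower number from compound 2 to compound 3 (1.62 log units; beyond the scatter) runs toward a lower number; the reverse change, from compound 3 to compound 4, is therefore expected to run toward a much higher number, and it is likely that compound 4 is reported only as a limit. The expected step is a 42-fold higher number from compound 3 to compound 4 (1.62 log units; beyond the scatter). Compound 4 is accordingly estimated at 10000 nM, with a range from 2000 nM to 30000 nM.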

Compound 4, half-maximal inhibitory concentration: > 10000 nM
Compound 4: no number, only a limit; the forecaster's own chance of this, stated with the estimate: 70%; the middle value sits exactly at the limit.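

In this assay the thiophene now stays in place and only the sulfonyl gives way to a carbonyl, and this single change on an oxygen on an aromatic ring gives an at least 42-fold higher number from compound 3 to compound 4 (1.62 log units; beyond the scatter). The earlier steps shown here toward compound 3 replaced the carbonyl and the group on it together, leaving open whether the thiophene or the sulfonyl went with the measured number; here the thiophene on a carbonyl ester gives no number, and the sulfonyl is the part that separates compound 3 from compound 4. The steps among compound 1, compound 2 and compound 4 cannot be read, and all three carbonyl esters rest at the same limit: the limit of > 10000 nM in this assay, at which 3 of the 4 values shown sit.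

Among the compounds shown here, compound 3 remains the only compound with a number, which leaves open whether the sulfonate keeps its activity with phenyl or methyl on the sulfonyl in place of thiophen-2-yl. Also open, on these data alone, are how far the three carbonyl esters lie beyond their limit, and whether a sulfonamide, with nitrogen in place of the oxygen, would give a number in this assay.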